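This account rests on a few compounds, and the source may have more. Where it says the series, first, only, none or still open, it means among the compounds named here.

This account concerns a small set of compounds built on a shared core and follows one change, from compound 1 to compound 4. Among the compounds with values here, compound 1, `COc1ccc(N)c(C(=O)CCNC(C)=O)c1`, is the only member with a number: in a functional assay for inhibition of kynurenine 3-monooxygenase (Rattus norvegicus), tested at 1 mM (a lower number here means less inhibition, a higher number more inhibition at the concentration tested (going by the name of the read-out)), compound 1 gives 102%, an essentially complete response at the concentration tested. Two further compounds were reported without a result in this assay: compound 2, `Nc1ccc(Cl)cc1C(=O)CCNC(=O)C1CC1`, gives "not determined" (no result reported), and compound 3, `Nc1ccc(Cl)cc1C(=O)CCNC(=O)c1ccccc1`, gives "not determined" (no result reported), so they give no footing for comparison. Compound 1 therefore stands alone as the sole measured point, and it stands at the top of what the read-out can show.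

Compound 4, `COc1ccc(N)c(C(=O)CCNC(=O)c2ccccc2)c1`, differs from compound 1 in one place: phenyl in place of methyl on a carbonyl carbon. Within the data shown here, no step between two measured compounds is available, so the size of this step can only be expected, not read off. Because compound 1 already sits at the full response with 102%, there is no room for a rise beyond the scatter; the only open question is whether the phenyl in place of methyl on a carbonyl carbon costs some inhibition. A modest decrease, or none beyond the scatter, is the expected outcome, with a number 12 percentage points lower from compound 1 to compound 4 (beyond the scatter) as the estimated step. Compound 4 is thus expected to give about 90% in this assay, within a range from 65% to 102%.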

Compound 4, a percentage reported as inhibition, at one concentration (the size of the read-out at that concentration, not a potency): 97.2%
Beside the measured number, compound 4's estimate is 7.2 percentage points below it; the measured number falls inside the stated range.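

In this assay, replacing methyl with phenyl on a carbonyl carbon whose other neighbour is an amide-type nitrogen gives a number 4.8 percentage points lower from compound 1 to compound 4 (within the scatter), so this read-out does not separate the two compounds at the concentration tested. Compound 1 alone could not show this: the position accepts a six-membered aromatic ring of carbon only in place of a single carbon, with no loss beyond the scatter. No evidence is available that explains this result.

Steps involving compound 2 and compound 3 cannot be read, so the compounds shown do not tell whether the same exchange would give a similar result with chlorine in place of the methoxy group on the shared core. Since both measured compounds stand close to the full response at a single concentration, any difference in potency between them remains unresolved, and the compounds shown also leave open how a longer chain such as n-butyl, an amine or a carboxylic acid would fare on that carbonyl carbon.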